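Adding a Third Chloro Group to a Salicylanilide

The compounds below may be only part of what the source reports. "The series", "measured", "known", "first", "only" and "open" are said of these compounds alone.

Four compounds share a core carrying a hydroxyl and a chloro group, joined through an amide to a second aromatic ring. In an ADME assay on cells (Macrophage, Mus musculus) for cytotoxicity, read by resazurin assay, with a stated time of 3 days (a higher number here means a weaker inhibitor, a lower number a stronger inhibitor), compound 1 `O=C(Nc1ccc(F)cc1)c1cc(Cl)ccc1O` gives 17000 nM. Compound 2 `O=C(Nc1ccc(F)c(Cl)c1)c1cc(Cl)ccc1O` differs from compound 1 by chloro in place of hydrogen on an aromatic carbon; in this assay compound 2 gives 4400 nM, a step of a 3.9-fold lower number from compound 1 to compound 2 (0.59 log units; beyond the scatter). Compound 3 `O=C(Nc1cc(Cl)cc(Cl)c1)c1cc(Cl)ccc1O` gives 3100 nM; how it differs from compound 1 is not broken down here. Compound 4 `O=C(Nc1cc(Cl)c(Cl)c(Cl)c1)c1cc(Cl)ccc1O` differs from compound 3 by chloro in place of hydrogen on an aromatic carbon. This is the same kind of change as from compound 1 to compound 2, though the place differs: there the entering chloro was ortho to a fluoro group and meta to a large group, here it is ortho to two chloro groups and para to a large group. Because a 3.9-fold lower number from compound 1 to compound 2 (0.59 log units; beyond the scatter) was modest, compound 4 is expected to show a step of a 2.1-fold lower number from compound 3 to compound 4 (0.32 log units; beyond the scatter), and an estimated value of 1500 nM in this assay, between 700 nM and 4000 nM.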

Compound 4, half-maximal inhibitory concentration: 5400 nM
Estimate against measurement, compound 4: 3.6-fold (0.56 log units) below; measured number above the stated range.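

In this assay, compound 4 cannot be told apart from compound 3, with a step of a 1.7-fold higher number from compound 3 to compound 4 (0.24 log units; within the scatter). Putting chloro in place of hydrogen therefore did not carry a fixed step from one core to the other: the same change on two cores in this assay, a 3.9-fold lower number (0.59 log units; beyond the scatter) from compound 1 to compound 2 and a 1.7-fold higher number (0.24 log units; within the scatter) from compound 3 to compound 4, 6.7-fold (0.83 log units) apart, beyond the scatter of two such steps. This does not show what sets the two steps apart, since the cores differ and so does the place of the entering chloro, which in compound 4 is ortho to two chloro groups and para to a large group.

The compounds shown leave open how an amine or a carboxylic acid at that same place would read in this assay. They also leave open whether a second core would follow either step.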